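Amine change on the amide chain: compound 3 to compound 4

A few compounds are considered here, and "the series" means these few. Any claim that something is new, unique, unknown or untested is made for them only; others in the source may bear on it.

In a functional assay on HepG2 cells (Homo sapiens) for cytotoxicity, read by MTT assay, with a stated time of 72 h (a lower number here means a stronger inhibitor, a higher number a weaker inhibitor), compound 3 (`Cc1ccc(-c2nc3cc(NC(=O)CCN4CCCCC4)ccc3[nH]2)cc1`) gives 11900 nM. For the measured compounds named here, the only other number belongs to compound 2 (`CCN1CCN(CCC(=O)Nc2ccc3[nH]c(-c4ccc(C)cc4)nc3c2)CC1`), which gives 14600 nM, and the two values lie within the scatter of each other. Compound 1 (`CCN1CCN(CC(=O)Nc2ccc3[nH]c(-c4cccn4C)nc3c2)CC1`) gives > 50000 nM, which is a limit of the assay and not a number.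

Compound 4 (`Cc1ccc(-c2nc3cc(NC(=O)CN4CCCC4)ccc3[nH]2)cc1`) differs from compound 3 as follows: pyrrolidin-1-yl in place of (piperidin-1-yl)methyl on a saturated chain carbon bound to a carbonyl carbon. In words, pyrrolidin-1-yl stands in place of (piperidin-1-yl)methyl on a saturated chain carbon bound to a carbonyl carbon. The same difference, cut one bond further out, reads 2-(piperidin-1-yl)ethyl to (pyrrolidin-1-yl)methyl.

Going by the values given here, one measured step bears on this change: a 1.2-fold lower number from compound 2 to compound 3 (0.09 log units; within the scatter). That step exchanges the ring amine on the chain and stays within the scatter. Among the compounds with values here, no measured step covers the rest of the change, so this reading is only partial support. On that basis, no step beyond the scatter is expected in this assay, and no direction is favoured with confidence. The estimated step is a 1.3-fold higher number from compound 3 to compound 4 (0.10 log units; within the scatter). For compound 4 the expected value is 15000 nM. The estimated range for compound 4 runs from 6000 nM to 45000 nM.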

Compound 4, half-maximal inhibitory concentration: > 50000 nM
Compound 4: a limit, no number; the forecaster's own chance of this, stated with the estimate: 10%; middle value at least 3.3-fold (0.52 log units) away from the limit.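

The change from 2-(piperidin-1-yl)ethyl to (pyrrolidin-1-yl)methyl moves the read-out in this assay, giving an at least 4.2-fold higher number from compound 3 to compound 4 (0.62 log units; beyond the scatter), and the related change from the 4-ethylpiperazine chain gives an at least 3.4-fold higher number from compound 2 to compound 4 (0.53 log units; beyond the scatter). Among the steps at this position, these are the first to lie beyond the scatter, whereas the exchange of ring amine on the longer chain, a 1.2-fold lower number from compound 2 to compound 3 (0.09 log units; within the scatter), stays within it; the position therefore does respond to some changes, and here the number goes higher. Both steps are lower bounds only, because compound 4 sits at a limit of the assay and not at a number: the limit of > 50000 nM in this assay, at which 2 of the 4 values shown sit.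

The change joins two differences, a five-membered ring for a six-membered ring and a shorter link to the carbonyl carbon, and the compounds shown do not tell which of them carries the step. A 2-(pyrrolidin-1-yl)ethyl group or a (piperidin-1-yl)methyl group on the same amide would pull the two apart, and a 3-(piperidin-1-yl)propyl chain would test the longer direction.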